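This account rests on a few compounds, and the source may have more. Where it says the series, first, only, none or still open, it means among the compounds named here.

Three compounds have so far been measured in a functional assay on T47D cells (Homo sapiens) for inhibition, read by sulforhodamine B assay, with a stated time of 48 h, tested at 10 uM; on this read-out lower numbers stand for less inhibition and higher numbers for more inhibition at the one concentration tested (going by the name of the read-out):

compound 1, `Fc1ccc(-c2cn3ccnc3c(-c3ccc4ncn(C5CCCCC5)c4c3)n2)cc1`, gives 33.3%
compound 2, `Fc1ccccc1-c1cn2ccnc2c(-c2ccc3ncn(C4CCCCC4)c3c2)n1`, gives 77.2%
compound 3, `CCc1ccc(-c2cn3ccnc3c(-c3ccc4ncn(Cc5ccccc5)c4c3)n2)cc1`, gives 94.8%

Compound 3 stands highest of the three, beyond the scatter above compound 2 and further still above compound 1. Going by the values given here, the one single-point step among them, a number 43.9 percentage points higher from compound 1 to compound 2 (beyond the scatter), comes from moving the fluorine within the fluorophenyl group and is large.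

Compound 4, `Cc1cccc(-c2cn3ccnc3c(-c3ccc4ncn(Cc5ccccc5)c4c3)n2)c1`, differs from compound 3 by 3-methylphenyl in place of 4-ethylphenyl on an aromatic carbon. The change sits on the shared core next to the ring nitrogen, meta to a fused ring, and alters both the substituent and its place on the ring. Among the compounds with values here, the step of a number 43.9 percentage points higher from compound 1 to compound 2 (beyond the scatter) is the only measured guide, and it shows that the place of a substituent on this ring can matter strongly; no measured step compares an ethyl with a methyl. Because compound 3 already gives 94.8%, there is little room upward. The author therefore expects a modest decrease, a number 10.8 percentage points lower from compound 3 to compound 4 (beyond the scatter), that may yet fall within the scatter. For compound 4 the estimate is 84%, with a range from 62% to 98%.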

Compound 4, a percentage reported as inhibition, at one concentration (the size of the read-out at that concentration, not a potency) in the T47D assay: 86.1%
Beside the measured number, compound 4's estimate is 2.1 percentage points below it; the range from low to high includes it.
By their numbers in the T47D assay, from the lowest: compound 1; then compounds 2, 4 and 3 (each within the scatter of the next, the first and the last beyond it).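

In the T47D assay, putting 3-methylphenyl in place of 4-ethylphenyl gives a number 8.7 percentage points lower from compound 3 to compound 4 (within the scatter), so at this position a change of both the substituent and its place on the ring stays within the scatter, even though the fluorine move gave a number 43.9 percentage points higher from compound 1 to compound 2 (beyond the scatter), a large step in a pair that also differs from this one elsewhere in its structure. In a physicochemical assay for lipophilicity, using the shake flask method, in phosphate buffer, measured as octanol-water partition, with a stated time of 85 min, at pH 7.4 (on this read-out lower numbers stand for lower lipophilicity and higher numbers for higher lipophilicity), compound 3 gives 1.96 and compound 4 gives 2.16. In the physicochemical assay the same swap gives a number 0.20 log units higher from compound 3 to compound 4 (within the scatter), which is also within the scatter, so neither read-out separates compound 3 from compound 4. Nothing at hand offers an explanation for these results.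

The swap alters the chain and its place on the ring together, so the contribution of each remains unresolved. As far as these compounds go, how an amine or a carboxylic acid on this phenyl ring would read in the T47D assay also remains open.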